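The source may hold more compounds than are shown below. What is called first, only, known or untested is meant among the compounds shown, and "the series" means these compounds.

Measured so far in a functional assay on A-431 cells (Homo sapiens) for inhibition, read by MTT assay, with a stated time of 72 h; on this read-out higher numbers stand for weaker inhibition of growth and lower numbers for stronger inhibition of growth:

compound 1 `N#C/C(=C\c1c(F)c(F)c(F)c(F)c1F)C(=O)c1c[nH]c2ccccc12`: 19000 nM
compound 2 `COc1ccc(CNC(=O)/C(C#N)=C/c2ccco2)cc1`: 16000 nM
compound 3 `N#C/C(=C\c1ccco1)C(=O)NCc1ccc(Cl)c(Cl)c1`: reports only a limit, > 50000 nM

On the numbers given, compound 2 has the lowest of the two numerical values in this assay, though its nearest neighbour, compound 1, sits within the scatter of it, so no order between the two can be claimed. Compound 3 stands at a limit of the assay and gives no number (the limit of > 50000 nM in this assay, at which 1 of the 3 values shown sits).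

Compound 4 `COc1ccc(CNC(=O)/C(C#N)=C/c2ccc(-c3ccccc3)o2)cc1` differs from compound 2 in one place: phenyl in place of hydrogen on an aromatic carbon. Among the compounds with values here, no measured pair shows this kind of change, so the size of the step is untested. On the series as it stands, a moderate gain in growth inhibition is expected, but with wide uncertainty, and a step that stays within the scatter cannot be excluded. The expected step from compound 2 to compound 4 in this assay is a 2.0-fold lower number from compound 2 to compound 4 (0.30 log units; within the scatter). For compound 4 the estimated value in this assay is 8000 nM, with a range from 2500 nM to 30000 nM.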

Compound 4, concentration for 50% growth inhibition: > 100000 nM
Compound 4 gave a limit, no number (the forecaster's own chance of this, stated with the estimate: 15%); middle value at least 12-fold (1.09 log units) from the limit.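

In this assay compound 4 reports only a limit, > 100000 nM, and that limit stands alone among the compounds shown: the limit of > 100000 nM in this assay, at which 1 of the 4 values shown sits.

Within the data shown here, this gives the first measured step at this position, phenyl in place of hydrogen on an aromatic carbon next to the ring oxygen: an at least 6.2-fold higher number from compound 2 to compound 4 (0.79 log units; beyond the scatter). On the shared core, this change therefore weakens growth inhibition rather than strengthening it, and the full size of the loss cannot be read from a limit.

On these data alone, whether a methyl group or a chlorine atom on the same carbon would keep the growth inhibition of compound 2 stays open, as does whether a phenyl carrying an amine or a carboxylic acid would. As far as these compounds go, the finding rests on one pair, so the effect of this change with the amide partner of compound 3 also stays open.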